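From 4-methylphenyl to pyridin-3-yl: compound 4 awaits measurement

A few compounds are considered here, and "the series" means these few. Any claim that something is new, unique, unknown or untested is made for them only; others in the source may bear on it.

Measured so far in an ADME assay on HEK293 cells (Homo sapiens) for cytotoxicity, with a stated time of 72 h; on this read-out lower numbers stand for an effect already at smaller amounts and higher numbers for an effect only at larger amounts of compound:
Compound 1 (`CCc1ccc(NC(=O)Nc2cc(C)nc3ccccc23)cc1`) gives 16000 nM as a number
Compound 2 (`CC(=O)c1ccc(NC(=O)Nc2cc(C)nc3ccccc23)cc1`) gives > 25000 nM as a limit
Compound 3 (`Cc1ccc(NC(=O)Nc2cc(C)nc3ccccc23)cc1`) gives > 25000 nM as a limit

Compound 3 therefore stands at the limit of > 25000 nM in this assay, at which 2 of the 3 values shown sit, and has no exact number. Compound 4 (`Cc1cc(NC(=O)Nc2cccnc2)c2ccccc2n1`) carries pyridin-3-yl in place of 4-methylphenyl on an amide-type nitrogen. Two measured steps alter that same aromatic group: an at least 1.5-fold higher number from compound 1 to compound 2 (0.19 log units; that floor lies within the scatter) and an at least 1.5-fold higher number from compound 1 to compound 3 (0.19 log units; that floor lies within the scatter). A third is a step that the two limits leave unreadable from compound 2 to compound 3. None of them replaces the ring itself, so they guide this swap only loosely. No step beyond the scatter is expected in this assay, and no direction can be named. The expected change is a step that the limit leaves unreadable from compound 3 to compound 4 in size. The estimated value for compound 4 is 28000 nM, with an expected range from 14000 nM to 56000 nM.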

Compound 4, half-maximal effective concentration: > 25000 nM
Compound 4 was reported as a limit (the forecaster's own chance of this, stated with the estimate: 75%); the middle value lies beyond the limit too.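

Compound 3 and compound 4 each give only a limit, not an exact number, so no step between them can be read: the limit of > 25000 nM in this assay, at which 3 of the 4 values shown sit.

The compounds shown leave open whether pyridin-3-yl in place of 4-methylphenyl changes the half-maximal effective concentration at all.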